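A Smaller Chain in Place of a Ring

The source may hold more compounds than are shown below. What is called first, only, known or untested is meant among the compounds shown, and "the series" means these compounds.

This study concerns an assay on isolated protein for inhibition of myosin-2 (Bos taurus), read by spectrophotometry, with a stated time of 24 min; a lower number here means a stronger inhibitor, a higher number a weaker inhibitor. Compound 1, with the structure `C/C(=N\CC1CCCCC1)c1c(O)c2ccccc2[nH]c1=O`, was tested there. In this assay compound 1 gives only a limit, >= 100000 nM. Two further compounds share much of the same core. Compound 2, with the structure `C/C(=N\Cc1ccccn1)c1c(O)c2ccccc2oc1=O`, gives 22000 nM in this assay. Compound 3, with the structure `C/C(=N\OCc1ccccc1)c1c(O)c2ccccc2oc1=O`, gives only a limit in this assay, >= 100000 nM. So two of the three values sit at a limit (the limit of >= 100000 nM in this assay, at which 2 of the 3 values shown sit), and compound 1 stands at that limit rather than at a measured number. Among the measured compounds shown here, no two measured compounds differ in one place only, so no step size can be read from the numbers at hand.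

Compound 4, with the structure `CCC/N=C(\C)c1c(O)c2ccccc2[nH]c1=O`, remains to be measured. It differs from compound 1 as follows: ethyl in place of cyclohexyl on a saturated chain carbon bound to a double-bonded nitrogen. Because compound 1 gives >= 100000 nM in this assay, the change is expected to leave compound 4 near that limit as well. Compound 4 is expected to give about 100000 nM in this assay, within a range from 30000 nM to 300000 nM. The expected step of a number no higher from compound 1 to compound 4 (the limit leaves the size open) is therefore small, no larger than the usual scatter, in no clear direction.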

Compound 4, half-maximal inhibitory concentration: >= 100000 nM
Compound 4: only a limit was reported; the forecaster's own chance of this, stated with the estimate: 70%; the middle value lies on the limit itself.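

In this assay compound 4 gives >= 100000 nM, which is a limit and not a number. Among the compounds shown here, compound 1 also gives only a limit, and no step between compound 1 and compound 4 can be read. The compounds shown leave open whether ethyl in place of cyclohexyl changes the inhibition at all.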